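Chain steps from ethyl to isopropyl: series notes

The source may report more compounds than this note shows. Statements on the series, on what has been measured and on what is new or still open speak of the compounds shown alone.

Measured in a functional assay on KBVIN cells (Homo sapiens) for antiproliferative activity, read by sulforhodamine B assay, with a stated time of 3 days; a lower number here means that less compound is needed, a higher number that more compound is needed for the effect
- compound 1 `CCC1=C(O)c2c(oc(-c3ccc(C)cc3)cc2=O)C(CC)(CC)C1=O` gives 0.08 uM
- compound 2 `CCC1=C(O)c2c(oc(-c3ccc(CC)cc3)cc2=O)C(CC)(CC)C1=O` gives 0.07 uM
- compound 3 `CCCc1ccc(-c2cc(=O)c3c(o2)C(CC)(CC)C(=O)C(CC)=C3O)cc1` gives 12.2 uM

Compound 2 sits at the low end of the numbers together with compound 1, and a 1.1-fold lower number from compound 1 to compound 2 (0.06 log units; within the scatter) does not separate the two. The remaining step, a 170-fold higher number from compound 2 to compound 3 (2.24 log units; beyond the scatter), is large.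

The next change is methyl in place of hydrogen on a saturated chain carbon bound to an aromatic carbon and a saturated chain carbon, ethyl to isopropyl, giving compound 4 `CCC1=C(O)c2c(oc(-c3ccc(C(C)C)cc3)cc2=O)C(CC)(CC)C1=O`.

Among the measured compounds shown here, two measured steps bear on this. The same kind of exchange on the chain carbon bound to the aromatic carbon gave a 1.1-fold lower number from compound 1 to compound 2 (0.06 log units; within the scatter), while lengthening the chain gave a 170-fold higher number from compound 2 to compound 3 (2.24 log units; beyond the scatter). No branched chain has been measured, so the data do not settle which of these compound 4 will follow. A rise in this assay is expected, probably beyond the scatter. Compound 3 gives 12.2 uM, and the rise is expected to stay short of that full jump. The expected change is a 14-fold higher number from compound 2 to compound 4 (1.15 log units; beyond the scatter). For compound 4 the estimate is 1 uM, with an expected range of 0.1 uM to 12 uM.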

Compound 4, concentration for half-maximal effect: 1.08 uM
The estimate for compound 4 lay 1.1-fold (0.03 log units) below the measured number; the measured number falls inside the stated range.
By their numbers in this assay, from the lowest: compounds 2 and 1 (each within the scatter of the next); then compound 4; then compound 3.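

At this position, adding a carbon is not a uniform change. a 15-fold higher number from compound 2 to compound 4 (1.19 log units; beyond the scatter) is large, whereas the comparable exchange gave only a 1.1-fold lower number from compound 1 to compound 2 (0.06 log units; within the scatter) and stayed within the scatter. The arrangement of the carbons also counts, since isopropyl in place of propyl gives an 11-fold lower number from compound 3 to compound 4 (1.05 log units; beyond the scatter) and a 14-fold higher number from compound 1 to compound 4 (1.13 log units; beyond the scatter) places compound 4 well clear of the low end, so compound 4 stands apart from both the short chains and the propyl chain.

Going by these compounds, whether a tert-butyl group, a cyclopropyl ring or a longer chain such as butyl would continue this pattern stays open, as does the outcome with an amine or a methoxy group at this position. Nothing available offers an explanation for any of these steps.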